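The source may report more compounds than this note shows. Statements on the series, on what has been measured and on what is new or still open speak of the compounds shown alone.

The account starts from compound 1, `CN(C)c1nc2cc(Cl)c(Cl)cc2n1COC(CO)CO`. In a functional assay on KB cells (Homo sapiens) for inhibition (on this read-out higher numbers stand for weaker inhibition and lower numbers for stronger inhibition), compound 1 gives > 100000 nM, which is a limit of the assay and not a number. Going by the values given here, compound 2, `Nc1nc2c(Cl)c(Cl)ccc2n1COC(CO)CO`, is the only other compound with a result. In this assay compound 2 gives > 100000 nM, again a limit rather than a measured value. Compound 1 therefore stands at the limit that both results share, (the limit of > 100000 nM in this assay, at which 2 of the 2 values shown sit), and no order between the two compounds can be read from them. Among the compounds with values here, no pair of measured compounds differs in a single place, so no measured step is available. The unmeasured compound 3, `OCC(CO)OCn1c(Br)nc2cc(Cl)c(Cl)cc21`, carries the change (bromo in place of dimethylamino on an aromatic carbon), that is, bromo in place of dimethylamino on an aromatic carbon. With both known results sitting at the limit, the step in this assay is expected to amount to a number no higher from compound 1 to compound 3 (the limit leaves the size open), none beyond the usual scatter in either direction. Compound 3 is accordingly expected to give about 100000 nM in this assay, within 30000 nM to 300000 nM, most likely reported once more as a limit.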

Compound 3, half-maximal inhibitory concentration: > 100000 nM
Compound 3 gave a limit, no number; the forecaster's own chance of this, stated with the estimate: 70%; the middle value sits exactly at the limit.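

Compound 3, like compound 1, sits at a limit of the assay and not at a number, so no step from compound 1 to compound 3 can be read in this assay: the limit of > 100000 nM in this assay, at which 3 of the 3 values shown sit.

The compounds shown leave open how strongly any of them inhibits, and whether bromo or dimethylamino on that aromatic carbon makes any difference.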